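Amide side chain: from compound 3 to compound 4

The source may report more compounds than this note shows. Statements on the series, on what has been measured and on what is new or still open speak of the compounds shown alone.

Values in a functional assay on HepG2 cells (Homo sapiens) for antiproliferative activity, read by MTT assay, with a stated time of 48 h; on this read-out lower numbers stand for stronger inhibition and higher numbers for weaker inhibition:
compound 1 `CCn1c(C(=O)NCCN)ccc1C(CC)(CC)c1ccc(OCCC(O)(CC)CC)c(C)c1`: 1590 nM
compound 2 `CCOC(=O)CN(C)C(=O)c1ccc(C(CC)(CC)c2ccc(OCCC(O)(CC)CC)c(C)c2)n1CC`: 25300 nM
compound 3 `CCOC(=O)C(CC(=O)OC)NC(=O)c1ccc(C(CC)(CC)c2ccc(OCCC(O)(CC)CC)c(C)c2)n1CC`: > 50000 nM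

For compound 3 the entry > 50000 nM is a limit of the assay, not a number. Compound 4 `CCC(C)C(CO)NC(=O)c1ccc(C(CC)(CC)c2ccc(OCCC(O)(CC)CC)c(C)c2)n1CC` carries 1-(hydroxymethyl)-2-methylbutyl on the amide-type nitrogen: a group of 7 heavy atoms (6 carbon, 1 oxygen; no ring) in place of a group of 11 heavy atoms (7 carbon, 4 oxygen; no ring), on an amide-type nitrogen. Among the compounds with values here, two measured steps bear on this change. The first, an at least 31-fold higher number from compound 1 to compound 3 (1.49 log units; beyond the scatter), is large, so the side chain at this nitrogen can shift the read-out strongly. The second, an at least 1.9-fold higher number from compound 2 to compound 3 (0.29 log units; that floor lies within the scatter), has a floor within the scatter. The expectation leans on compound 2, at 25300 nM, rather than on compound 1. The expected step, towards a lower number, is an at least 2.5-fold lower number from compound 3 to compound 4 (0.39 log units; beyond the scatter). For compound 4 the estimated value in this assay is 20000 nM, with an expected range of 6000 nM to 50000 nM.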

Compound 4, half-maximal inhibitory concentration: > 50000 nM
Compound 4 ended at the assay's limit; the forecaster's own chance of this, stated with the estimate: 30%; middle value at least 2.5-fold (0.39 log units) from the limit.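

The step between compound 3 and compound 4 cannot be read, as both values are limits of the assay: the limit of > 50000 nM in this assay, at which 2 of the 4 values shown sit.

The large step of an at least 31-fold higher number from compound 1 to compound 4 (1.49 log units; beyond the scatter) shows that the gap to compound 1 does not depend on the ester-bearing chain of compound 3, since 1-(hydroxymethyl)-2-methylbutyl also gives it. The step of an at least 1.9-fold higher number from compound 2 to compound 4 (0.29 log units; that floor lies within the scatter) sets no order between those two compounds.

On these data alone, whether the amine of 2-aminoethyl is needed for the value of compound 1 stays open. A dimethylamine on a longer chain, or a carboxylic acid on the same chain, on this amide-type nitrogen would bear on that.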